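Bromo to chloro swap on the fused ring, two cores

The compounds below may be only part of what the source reports. "The series", "measured", "known", "first", "only" and "open" are said of these compounds alone.

Compound 1 `COc1ccc(C2=NN(C3=NC(=O)/C(=C4\C(=O)Nc5ccc(Br)cc54)S3)C(c3ccc(Cl)cc3)C2)cc1` and compound 2 `COc1ccc(C2=NN(C3=NC(=O)/C(=C4\C(=O)Nc5ccc(Cl)cc54)S3)C(c3ccc(Cl)cc3)C2)cc1` share one core; compound 3 `CN(C)c1ccc(C2CC(c3ccccc3)=NN2C2=NC(=O)/C(=C3\C(=O)Nc4ccc(Br)cc43)S2)cc1` and compound 4 `CN(C)c1ccc(C2CC(c3ccccc3)=NN2C2=NC(=O)/C(=C3\C(=O)Nc4ccc(Cl)cc43)S2)cc1` share another. The difference between the two cores is not broken down here. In a functional assay on cells (Cancer cell lines, Homo sapiens) for cytotoxicity, read by sulforhodamine B assay, with a stated time of 48 h (on this read-out higher numbers stand for weaker inhibition of growth and lower numbers for stronger inhibition of growth), compound 1 gives 400 nM, and compound 2 gives 470 nM. One change separates them: chloro in place of bromo on an aromatic carbon. That change made a 1.2-fold higher number from compound 1 to compound 2 (0.07 log units; within the scatter). In this assay compound 3 gives 510 nM; the numbers of compound 3 and compound 2 lie within the scatter of each other, and so do those of compound 3 and compound 1. Compound 4 is not yet measured. It differs from compound 3 by the same change: chloro in place of bromo on an aromatic carbon. The place is described in the same words for both pairs, so the change counts as the same. Because a 1.2-fold higher number from compound 1 to compound 2 (0.07 log units; within the scatter) stayed within the scatter, the step in this assay is expected to be small as well, a 1.2-fold higher number from compound 3 to compound 4 (0.07 log units; within the scatter). On that basis compound 4 is estimated at 600 nM, with an expected range of 350 nM to 1000 nM.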

Compound 4, concentration for total growth inhibition: 530 nM
For compound 4 the middle estimate is 1.1-fold (0.05 log units) above the measured one; the range from low to high includes it.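

In this assay, chloro in place of bromo on an aromatic carbon gives a 1.0-fold higher number from compound 3 to compound 4 (0.02 log units; within the scatter), a small step on the second core, as on the first. Set side by side, the two steps agree: the same change on two cores in this assay, a 1.2-fold higher number (0.07 log units; within the scatter) from compound 1 to compound 2 and a 1.0-fold higher number (0.02 log units; within the scatter) from compound 3 to compound 4, 1.1-fold (0.05 log units) apart, within the scatter of two such steps. This shows that, in this one read-out, the swap carries from the core of compound 1 to the core of compound 3 without a step beyond the scatter; it does not show that bromo and chloro differ at all, nor does it show how a change with a larger step would carry, or how this swap would behave on any third core.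

The compounds shown hold only bromo and chloro at this place, which leaves open whether fluoro, a methyl group or an amine there would step beyond the scatter. Also open, on these data alone, is whether such a step would keep its size on both cores.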